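One Methyl Fewer on the Amide Compound

The compounds below may be only part of what the source reports. "The series", "measured", "known", "first", "only" and "open" are said of these compounds alone.

In an assay on NIH3T3 cells with Urotensin-2 receptor (Homo sapiens) as the target (a higher number here means a larger maximal response, a lower number a smaller maximal response), three compounds have already been measured. Compound 1 `Cc1ccc(C)c(C(=O)OC(CCN(C)C)c2ccc(Cl)cc2)c1` gives 86%. Compound 2 `Cc1cc(C)c(C(=O)OC(CCN(C)C)c2ccc(Cl)cc2)cc1C`, which carries one more methyl on its aromatic ring, gives 60% in this assay. The step between them is a number 26 percentage points higher from compound 2 to compound 1 (beyond the scatter), the change being (hydrogen in place of methyl on an aromatic carbon). Compound 3 `Cc1cc(C)c(C(=O)NC(CCN(C)C)c2ccc(Cl)cc2)cc1C` has a different core; the difference between the cores of compound 2 and compound 3 is not broken down here. In this assay compound 3 gives 159%, the highest of the three values, beyond the scatter above both others.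

Compound 4 `Cc1ccc(C(=O)NC(CCN(C)C)c2ccc(Cl)cc2)c(C)c1` has not yet been measured in this assay. It differs from compound 3 by hydrogen in place of methyl on an aromatic carbon. This is the same kind of change as from compound 2 to compound 1, but not the same: in compound 2 the leaving methyl sits meta to a methyl group and para to a large group, whereas in compound 3 it sits meta to a large group and para to a methyl group. The step expected here is a number 11 percentage points higher from compound 3 to compound 4 (beyond the scatter), a rise kept modest and given wide room because a number 26 percentage points higher from compound 2 to compound 1 (beyond the scatter) was made at a different place on the ring and on a different core. Compound 4 is therefore expected to give about 170% in this assay, with the likely range reaching from 130% to 215%.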

Compound 4, largest response reached (reported as efficacy), in percent of the reference or control that the assay uses: 147%
Estimate against measurement, compound 4: 23 percentage points above, within the range that was stated.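

In this assay, replacing this ring methyl with hydrogen on the amide compound gives a number 12 percentage points lower from compound 3 to compound 4 (beyond the scatter), so the change does not raise the maximal response here as it did on the core of compound 2. Set side by side, the two steps show that this change cannot be carried from one core to the other as a fixed amount, or even with a fixed direction: the same change on two cores in this assay, a number 26 percentage points higher (beyond the scatter) from compound 2 to compound 1 and a number 12 percentage points lower (beyond the scatter) from compound 3 to compound 4, 38 percentage points apart, beyond the scatter of two such steps. They do not show that the core alone sets the outcome, as the methyl that leaves also sits at a different place on the ring in each pair, and a single pair on each core cannot separate these two differences.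

The compounds shown leave open how the step would run if the methyl left the same place on the ring on both cores. They also leave open what the maximal response would be with a methoxy group or a fluorine atom in place of the methyl that sits meta to a large group and para to a methyl group.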